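Furan Amide Replacing a Bromopyridyl Urea Arm

The source may hold more compounds than are shown below. What is called first, only, known or untested is meant among the compounds shown, and "the series" means these compounds.

Compound 1, `CCOC(=O)c1csc2nc(-c3ccc(NC(=O)Nc4ccccc4)cc3)cn12`: > 20000 nM
Compound 2, `CCOC(=O)c1csc2nc(-c3ccc(NC(=O)Nc4ccc(Br)cn4)cc3)cn12`: 2440 nM
Compound 3, `CCOC(=O)c1csc2nc(-c3ccc(NC(=O)c4ccco4)cc3)cn12`: not yet measured

In a functional assay on MV4-11 cells (Homo sapiens) for cytotoxicity, read by MTT assay, with a stated time of 72 h (on this read-out lower numbers stand for stronger inhibition and higher numbers for weaker inhibition), compound 1 reaches only a limit of the assay, > 20000 nM. Among the compounds with values here, compound 2 gives the single real number in this assay, 2440 nM. Within the data shown here, the one measured step, an at least 8.1-fold lower number from compound 1 to compound 2 (0.91 log units; beyond the scatter), shows that the group on the amide-type nitrogen moves the read-out strongly, with the phenyl partner sitting at the limit (the limit of > 20000 nM in this assay, at which 1 of the 2 values shown sits).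

Compound 3 is `CCOC(=O)c1csc2nc(-c3ccc(NC(=O)c4ccco4)cc3)cn12`. The change from compound 2 is furan-2-yl in place of (5-bromopyridin-2-yl)amino on a carbonyl carbon. Among the measured compounds shown here, no measured step covers this exact replacement, but the step from compound 1 to compound 2 bears on it: removing the 5-bromopyridin-2-yl partner cost a large amount, and compound 3 lacks that partner entirely. A step of comparable size upward is therefore expected, a 4.9-fold higher number from compound 2 to compound 3 (0.69 log units; beyond the scatter). Compound 3 is expected to give about 12000 nM in this assay, within 3000 nM to 50000 nM, with a fair chance of only a limit.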

Compound 3, half-maximal inhibitory concentration: 9920 nM
The estimate for compound 3 lay 1.2-fold (0.08 log units) above the measured number, and the stated range covers the measured number.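

Replacing (5-bromopyridin-2-yl)amino on the carbonyl carbon with furan-2-yl gives a 4.1-fold higher number from compound 2 to compound 3 (0.61 log units; beyond the scatter), so in this assay the bromopyridyl urea arm stays ahead of this furan amide. Compound 1 stays at a limit of the assay, > 20000 nM. The furan-2-yl partner does give a measured number, yet the step, an at least 2.0-fold lower number from compound 1 to compound 3 (0.30 log units; that floor lies within the scatter), leaves its order against the anilino partner unsettled.

This change swaps the ring and removes the amino nitrogen at once, so the two contributions remain unseparated. On these data alone, whether a 5-bromopyridin-2-yl ring set directly on the carbonyl carbon, a furan-2-ylamino group, or a chlorine in place of the bromine would hold the number stays open.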